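Biaryl amides with a hexanoic acid tail: Raji cell cytotoxicity

The source may report more compounds than this note shows. Statements on the series, on what has been measured and on what is new or still open speak of the compounds shown alone.

Measured compounds:
compound 1, `CC(C)N(Cc1cccc(OCCCCCC(=O)O)c1)C(=O)c1ccc(-c2cccc(N(C)C)c2)cc1`: > 26000 nM
compound 2, `CC(=O)c1cccc(-c2ccc(C(=O)N(Cc3cccc(OCCCCCC(=O)O)c3)C(C)C)cc2)c1`: > 26000 nM
compound 3, `CC(C)Oc1cccc(-c2ccc(C(=O)N(Cc3cccc(OCCCCCC(=O)O)c3)C(C)C)cc2)c1`: > 26000 nM

In an ADME assay on Raji cells (Homo sapiens) for cytotoxicity, read by CellTiter-Glo and resazurin assay, with a stated time of 72 h (a higher number here means that more compound is needed for the effect, a lower number that less compound is needed), compound 3 gives > 26000 nM, which is a limit of the assay and not a number. Compound 1 likewise gives > 26000 nM in this assay, a limit. Compound 2 gives > 26000 nM in this assay, also a limit. All three values therefore sit at the limit of > 26000 nM in this assay, at which 3 of the 3 values shown sit, and none of them ranks above or below another.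

Compound 4, `CC(C)N(Cc1cccc(OCCCCCC(=O)O)c1)C(=O)c1ccc(-c2ccc3cc[nH]c3c2)cc1`, is not yet measured. It differs from compound 3 in one place: 1H-indol-6-yl in place of 3-isopropoxyphenyl on an aromatic carbon.

The measured steps that bear on this position are a step that the two limits leave unreadable from compound 1 to compound 3 and a step that the two limits leave unreadable from compound 2 to compound 3, together with a step that the two limits leave unreadable from compound 1 to compound 2. Each of them is unreadable, since both ends rest on the same limit, so none of them gives a size or a direction for a change at this aromatic carbon. The data therefore offer no ground to expect a step beyond the scatter, in either direction, but also cannot rule one out.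

On this basis compound 4 is estimated to give 26000 nM in this assay, with a range from 8000 nM to 60000 nM. The step this estimate means, a number no higher from compound 3 to compound 4 (the limit leaves the size open), is expected to stay within the scatter, most likely as another limit.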

Compound 4, half-maximal effective concentration: > 26000 nM
Compound 4 gave a limit, no number; the forecaster's own chance of this, stated with the estimate: 75%; the middle value sits exactly at the limit.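

In this assay compound 4 gives > 26000 nM, a limit and not a number. Its steps to compound 1, compound 2 and compound 3 therefore cannot be read, and all four compounds rest on the same limit: the limit of > 26000 nM in this assay, at which 4 of the 4 values shown sit.

The compounds shown leave open whether any group at this aromatic carbon changes the value in this assay, and in which direction.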